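Swapping the Ring on the Amide Carbonyl

The source may report more compounds than this note shows. Statements on the series, on what has been measured and on what is new or still open speak of the compounds shown alone.

Measured so far:
compound 1 `O=C(NC[C@@H]1C[C@@H]2C=C[C@@H]1C2)NS(=O)(=O)N1CCC(CCNC(=O)c2cscn2)CC1`: 37%
compound 2 `CCCNC(=O)NS(=O)(=O)N1CCC(CCNC(=O)c2cccc3c2OCCO3)CC1`: 25%

Of the compounds shown here, two have been tested in a functional assay on the whole organism (blood) with Rattus norvegicus as the target, with stated times of 24 h and 1 h, at a dose of 15 mg/kg by the intraperitoneal route; on this read-out higher numbers stand for a stronger effect at the one dose given and lower numbers for a weaker effect. Compound 1 gives 37%, the higher of the two numbers. Compound 2 gives 25%, a result that sits below compound 1 by more than the usual scatter, so the gap between them counts as a real difference. The two compounds differ in several places at once, so no single structural change can be tied to that gap.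

Compound 3 `Cn1cc(C(=O)NCCC2CCN(S(=O)(=O)NC(=O)NC[C@@H]3C[C@@H]4C=C[C@@H]3C4)CC2)c(=O)n(C)c1=O` has not been measured. It keeps the core of compound 1 and changes only the group on the carbonyl carbon next to the amide-type nitrogen:

a group of 10 heavy atoms (6 carbon, 2 nitrogen, 2 oxygen; one six-membered aromatic ring with 2 hetero atoms) in place of a group of 5 heavy atoms (3 carbon, 1 nitrogen, 1 sulfur; one five-membered aromatic ring with 2 hetero atoms), on a carbonyl carbon

Among the measured compounds shown here, with no measured step of this kind available, the expectation rests on the single value of compound 1. The step of a number 3 percentage points lower from compound 1 to compound 3 (within the scatter) is expected to stay within the scatter, with no clear direction. Compound 3 is therefore estimated at 34%, in a range from 15% to 55%.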

Compound 3, a percentage reported as activity, at one dose (the size of the read-out at that dose, not a potency): 32%
Compound 3: middle estimate off by 2 percentage points, on the high side; the measured number falls inside the stated range.
By their numbers in this assay, from the lowest: compounds 2, 3 and 1 (each within the scatter of the next, the first and the last beyond it).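

In this assay, exchanging the 1,3-thiazol-4-yl group on the carbonyl carbon for a six-membered aromatic ring with 2 hetero atoms gives a number 5 percentage points lower from compound 1 to compound 3 (within the scatter). Among the compounds shown here, this is the first step at this position that can be read on its own, and it shows that a group of 10 heavy atoms, with 4 hydrogen-bond acceptors, can stand in place of one of 5 heavy atoms, with 2 hydrogen-bond acceptors, without a difference that rises above the scatter at this one dose. No measurement at hand explains why these two quite different groups give values that cannot be told apart.

On these data alone, one step on the core of compound 1 cannot establish a trend, so it remains open whether other groups on this carbonyl carbon would also fall within the scatter of compound 1. A plain phenyl ring, a ring carrying a carboxylic acid or a short chain ending in an amine could show whether this position responds to a change in the kind of group, and not only to a change between these two rings.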